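This account rests on a few compounds, and the source may have more. Where it says the series, first, only, none or still open, it means among the compounds named here.

Measured so far:

- compound 1, `COc1cccc(-c2nc(SCC(=O)c3sc(-c4ccccc4)nc3C)[nH]c(=O)c2C#N)c1`: 80.3%
- compound 2, `COc1ccc(-c2nc(SCC(=O)c3sc(-c4ccccc4)nc3C)[nH]c(=O)c2C#N)cc1OC`: 21.4%
- compound 3, `COc1ccc(-c2nc(SCC(=O)c3sc(-c4ccc(Cl)cc4)nc3C)nc(N)c2C#N)cc1`: 17.8%

All three were tested in a functional assay on U-87MG ATCC cells for antiproliferative activity against U-87 MG (Homo sapiens), read by MTT assay, with a stated time of 48 h, tested at 50 uM; a lower number here means a stronger effect, a higher number a weaker effect of the compound at the concentration tested. Compound 2 and compound 1 differ in one place only: hydrogen in place of methoxy on an aromatic carbon. This single change made a large step, a number 58.9 percentage points higher from compound 2 to compound 1 (beyond the scatter), so the removal of that methoxy group went with a much weaker effect on the cells. Compound 3 and compound 2 show values within the usual scatter of each other, and the difference between their two cores is not broken down here.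

Compound 4, `Cc1nc(-c2ccc(Cl)cc2)sc1C(=O)CSc1nc(N)c(C#N)c(-c2ccccc2)n1`, has not yet been measured. It relates to compound 3 as compound 1 relates to compound 2: hydrogen in place of methoxy on an aromatic carbon. The place is not identical, though: in compound 2 the leaving methoxy sits ortho to a methoxy group and para to a large group, whereas in compound 3 it is only para to a large group. So this is the same kind of change, not the same change, and the cores around it also differ.

The expectation for compound 4 rests on the step from compound 2 to compound 1, a number 58.9 percentage points higher from compound 2 to compound 1 (beyond the scatter), which points towards a weaker effect once the methoxy leaves; with the surroundings not matching, a somewhat smaller step, a number 32.2 percentage points higher from compound 3 to compound 4 (beyond the scatter), is estimated here. For compound 4 the expected value in this assay is 50%, most likely between 20% and 85%.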

Compound 4, a percentage reported as activity, at one concentration (the size of the read-out at that concentration, not a potency): 15.2%
For compound 4 the middle estimate is 34.8 percentage points above the measured one; the whole stated range lies above it.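

On the newer pair, replacing the methoxy group with hydrogen gives a number 2.6 percentage points lower from compound 3 to compound 4 (within the scatter), so in this assay this swap leaves the read-out where it was, even though the same kind of swap had a large effect on the earlier pair. The effect of this change therefore does not carry over from one core to the other, and a result from one core is a poor guide to the other: the same change on two cores in this assay, a number 58.9 percentage points higher (beyond the scatter) from compound 2 to compound 1 and a number 2.6 percentage points lower (within the scatter) from compound 3 to compound 4, 61.5 percentage points apart, beyond the scatter of two such steps What this does not show is which difference between the two pairs is responsible, since they differ in their cores, in the chlorine on the far phenyl ring and in the groups around the methoxy that leaves, and two pairs cannot separate these or give a rule for the whole series.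

The compounds shown leave open how the core of compound 1 would behave with a single 4-methoxyphenyl group, which would bring the two pairs closer to a like-for-like comparison. They also leave open what a hydroxyl group or a carboxylic acid would do in place of the methoxy on either core, and whether the stronger and weaker effects seen at this single concentration would hold at other concentrations.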